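This account rests on a few compounds, and the source may have more. Where it says the series, first, only, none or still open, it means among the compounds named here.

In an ADME assay on MT4 cells (Homo sapiens) for cytotoxicity, read by MTT assay (on this read-out lower numbers stand for higher toxicity in this test and higher numbers for lower toxicity in this test), compound 1, `O=C(CSc1nncnc1-c1ccccc1Cl)c1ccc(Cl)c(Cl)c1`, gives 33000 nM, the lowest of the three numbers recorded so far. Compound 2, `O=C(CSc1nncnc1-c1cccc2ccccc12)Nc1ccc(Cl)cc1Cl`, gives 254000 nM in this assay, and compound 3, `CC(=O)c1ccc(NC(=O)CSc2nncnc2-c2cccc3ccccc23)c(Br)c1`, gives 133000 nM; both numbers stand well above that of compound 1. For the measured compounds named here, the only single-point step among the measured compounds is a 1.9-fold lower number from compound 2 to compound 3 (0.28 log units; within the scatter), which exchanges one aryl group for another on an amide-type nitrogen and leaves the number essentially unchanged.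

Compound 4, `O=C(CSc1nncnc1-c1ccccc1Cl)Nc1cccnc1Cl`, is built from compound 1 by the change ((2-chloropyridin-3-yl)amino in place of 3,4-dichlorophenyl on a carbonyl carbon). This change does not match any measured step: it turns the carbonyl of compound 1 into an amide-type linkage, as in compounds 2 and 3, while those two compounds also carry a different aryl group on the shared core. The step of a 1.9-fold lower number from compound 2 to compound 3 (0.28 log units; within the scatter) suggests that exchanging the aryl group on an amide-type nitrogen matters little, so the values of compounds 2 and 3 are the nearest guide. Compound 4 is therefore expected to give about 100000 nM in this assay, with a likely range from 35000 nM to 300000 nM. This estimate amounts to a 3.0-fold higher number from compound 1 to compound 4 (0.48 log units; beyond the scatter), a rise beyond the scatter, though it rests on an indirect comparison only.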

Compound 4, half-maximal cytotoxic concentration: 167000 nM
Compound 4: the middle estimate sits 1.7-fold (0.22 log units) below what was measured, within the range that was stated.
By their numbers in this assay, from the lowest: compound 1; then compounds 3, 4 and 2 (each within the scatter of the next).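

The earlier compounds shown here showed a step only on an amide-type nitrogen, and that step stayed within the scatter; here the exchange on the carbonyl carbon itself, with the rest of compound 1 held constant, gives in this assay a 5.1-fold higher number from compound 1 to compound 4 (0.70 log units; beyond the scatter). So the group on this carbonyl carbon can move the number beyond the scatter, and in this pair the move runs towards lower toxicity in this test, as the (2-chloropyridin-3-yl)amino group, with its hydrogen-bond donor and acceptor, replaces the 3,4-dichlorophenyl group, which has neither. Nothing available here bears on why the number moves at this position.

For the compounds shown here, the single step changes the link to the carbonyl carbon and the ring together, so it leaves open how much of the rise belongs to the amide hydrogen and how much to the ring with its hetero atom. From the compounds shown here alone, a (3,4-dichlorophenyl)amino group or a (2-chlorophenyl)amino group on the same carbonyl carbon would separate these two parts, and whether the rise holds with a naphthyl group on the shared core also remains open.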